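Selenocyanate carbamates: fluoro to chloro on the aryl ester

This account rests on a few compounds, and the source may have more. Where it says the series, first, only, none or still open, it means among the compounds named here.

Two compounds of the series have numbers. Compound 1 `N#C[Se]c1ccc(NC(=O)Oc2ccc(F)cc2)cc1` carries a fluorophenyl carbamate; in a functional assay on MCF7 cells (Homo sapiens) for cytotoxicity, read by MTT assay, with a stated time of 72 h (on this read-out higher numbers stand for weaker inhibition of growth and lower numbers for stronger inhibition of growth), compound 1 gives 8300 nM. Compound 2 `CCCOC(=O)Nc1ccc([Se]C#N)cc1` replaces the aryl ester with a propyl ester, and in this assay compound 2 gives 8000 nM. Compound 1 holds the highest of the two numbers, yet its nearest neighbour, compound 2, sits within the scatter of it, so the two values cannot be told apart and no order between them is claimed.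

Compound 3 `N#C[Se]c1ccc(NC(=O)Oc2ccc(Cl)cc2)cc1` is the next member to be measured. Against compound 1 the change is chloro in place of fluoro on an aromatic carbon, sitting on an aromatic carbon of a six-membered aromatic ring of carbon only, para to a large group. Going by the values given here, no step between measured compounds covers this swap, so the expectation rests on compound 1 alone. The exchange of one halogen for another at the same place is expected to give a step from compound 1 to compound 3 of a 1.2-fold lower number from compound 1 to compound 3 (0.07 log units; within the scatter), that is, none beyond the scatter, with at most a slight lean toward stronger inhibition of growth. Compound 3 is therefore estimated at 7000 nM, within a range of 3000 nM to 16000 nM.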

Compound 3, concentration for 50% growth inhibition in the MCF7 assay: 6000 nM
Estimate against measurement, compound 3: 1.2-fold (0.07 log units) above; the range from low to high includes it.
By their numbers in the MCF7 assay, from the lowest: compounds 3, 2 and 1 (each within the scatter of the next).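

In the MCF7 assay, the series now has its first step at this position, chloro in place of fluoro on an aromatic carbon, para to a large group: a 1.4-fold lower number from compound 1 to compound 3 (0.14 log units; within the scatter); this exchange of one halogen for the other therefore gives no difference that can be told from the scatter. In a physicochemical assay, with a stated time of 6 min, tested at 0.1 mg/mL (on this read-out lower numbers stand for less inhibition and higher numbers for more inhibition at the one concentration tested (going by the name of the read-out)), compound 1 gives > 25%, which is a limit of the assay and not a number. In the physicochemical assay compound 3 gives > 25%, which is likewise a limit of the assay.

The step between these two compounds on that read-out cannot be read, because both values stand at the same limit: the limit of > 25% in the physicochemical assay, at which 2 of the 2 values shown sit. Going by these compounds alone, still open is whether a bromo group, a methoxy group or an amine at this same place would give a step beyond the scatter in the MCF7 assay, since fluoro and chloro are the only groups compared here.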